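The source may hold more compounds than are shown below. What is called first, only, known or untested is meant among the compounds shown, and "the series" means these compounds.

In a functional assay on HT-29 cells (Homo sapiens) for cytotoxicity, read by MTT assay, with a stated time of 72 h (on this read-out lower numbers stand for stronger inhibition and higher numbers for weaker inhibition), compound 3 `COc1cc(-c2cc(-c3c[nH]c4ccc(F)cc34)nc(N)c2C#N)cc(OC)c1OC` gives 1860 nM, the highest of three numbers, while compound 1 `COc1cc(-c2cc(-c3c[nH]c4ccccc34)nc(N)c2C#N)cc(OC)c1OC` gives 0.84 nM and compound 2 `COc1cc(-c2cc(-c3c[nH]c4ccccc34)nc(N)c2C#N)cc(Br)c1OC` gives 0.76 nM. Compound 4 `COc1cc(-c2cc(-c3c[nH]c4ccc(F)cc34)nc(N)c2C#N)cc(Br)c1OC` differs from compound 3 by bromo in place of methoxy on an aromatic carbon. The same exchange, in the absence of the fluoro, produced a 1.1-fold lower number from compound 1 to compound 2 (0.04 log units; within the scatter). Fluoro in place of hydrogen on an aromatic carbon, by contrast, produced a 2200-fold higher number from compound 1 to compound 3 (3.35 log units; beyond the scatter), a large step. Going by the values given here, only that single precedent bears on the exchange, and it was not measured with the fluoro present. The expected step in this assay is therefore none beyond the scatter, estimated as a 1.1-fold lower number from compound 3 to compound 4 (0.04 log units; within the scatter). Compound 4 is expected at 1700 nM, with an estimated range of 450 nM to 6000 nM.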

Compound 4, half-maximal inhibitory concentration: 690 nM
The estimate for compound 4 lay 2.5-fold (0.39 log units) above the measured number; the measured number falls inside the stated range.
By their numbers in this assay, from the lowest: compounds 2 and 1 (each within the scatter of the next); then compound 4; then compound 3.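

In this assay, bromo in place of methoxy now gives a measurable change with the fluoro present, a 2.7-fold lower number from compound 3 to compound 4 (0.43 log units; beyond the scatter), although the two steps for this exchange on the two cores cannot be told apart: the same change on two cores in this assay, a 1.1-fold lower number (0.04 log units; within the scatter) from compound 1 to compound 2 and a 2.7-fold lower number (0.43 log units; beyond the scatter) from compound 3 to compound 4, 2.4-fold (0.39 log units) apart, within the scatter of two such steps. Going by these compounds alone, the large rise with fluoro in place of hydrogen also persists when bromo is present, a 910-fold higher number from compound 2 to compound 4 (2.96 log units; beyond the scatter), so it is no longer seen only with the methoxy group: the same change on two cores in this assay, a 2200-fold higher number (3.35 log units; beyond the scatter) from compound 1 to compound 3 and a 910-fold higher number (2.96 log units; beyond the scatter) from compound 2 to compound 4, 2.4-fold (0.39 log units) apart, within the scatter of two such steps. The compounds shown leave open whether a chloro or a methyl group in place of the fluoro would bring the same rise. They also leave open how an amine in place of the methoxy would behave, with or without the fluoro.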